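Fluoro to Chloro on the Amide Aryl Ring

This account rests on a few compounds, and the source may have more. Where it says the series, first, only, none or still open, it means among the compounds named here.

Measured so far:
compound 1 `O=C(NCc1ccc(CNS(=O)(=O)c2ccccc2)cc1)c1cccc(F)c1` gives 100 nM
compound 2 `Cc1ccc(S(=O)(=O)NCc2ccc(CNC(=O)c3ccc(F)cc3)cc2)cc1` gives 1 nM
compound 3 `COc1ccc(C(=O)NCc2ccc(CNS(=O)(=O)c3ccccc3)cc2)cc1` gives 1000 nM

Compound 2 has the lowest number of the three in an assay on MDA-MB-231 cells for binding affinity to C-X-C chemokine receptor type 4 (Homo sapiens), read by immunofluorescence and microscopy, with stated times of 10 min and 30 min; a lower number here means that less compound is needed, a higher number that more compound is needed for the effect; compound 1 lies well above it and compound 3 further still. Compound 4 `Cc1ccc(S(=O)(=O)NCc2ccc(CNC(=O)c3ccc(Cl)cc3)cc2)cc1` differs from compound 2 in one place: chloro in place of fluoro on an aromatic carbon.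

Within the data shown here, only one measured step exists, a 10-fold higher number from compound 1 to compound 3 (1.00 log units; beyond the scatter), and it changes the whole aryl group on the carbonyl carbon, not a single halogen, so it does not speak directly to a fluoro-to-chloro swap. Compound 1 and compound 2 differ in two places at once, so their gap cannot be assigned to either change. Among the measured compounds shown here, with no step that bears on the exchange of one halogen for another, the expectation is a step of no size beyond the scatter, a 1.5-fold higher number from compound 2 to compound 4 (0.18 log units; within the scatter).

Compound 4 is therefore estimated at 1.5 nM, within a range of 0.4 nM to 5 nM.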

Compound 4, effective concentration (reported as EC, without a stated level of effect): 10 nM
Compound 4: the middle estimate sits 6.7-fold (0.82 log units) below what was measured, and the stated range ends below it.
By their numbers in this assay, from the lowest: compound 2; then compound 4; then compound 1; then compound 3.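

In this assay, this place on the ring, an aromatic carbon para to a large group, proves sensitive to a single halogen: chloro in place of fluoro gives a 10-fold higher number from compound 2 to compound 4 (1.00 log units; beyond the scatter). Among these compounds, the earlier compounds could not show this, since their one measured step replaced the whole aryl group on the carbonyl carbon. Here one heavy atom is exchanged for another, with no change in rings, net charge or counted hydrogen-bond donors and acceptors, yet the step lies beyond the scatter; nothing available explains its size.

As far as these compounds go, it remains open how bromo, methyl or an amine at this place would compare with fluoro and chloro. From the compounds shown here alone, it is also open whether the same halogen exchange would give a similar step with the sulfonyl side of compound 1.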